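Stability in mouse liver cytosol across the amine substituent

The source may hold more compounds than are shown below. What is called first, only, known or untested is meant among the compounds shown, and "the series" means these compounds.

Measured compounds:
- compound 1 `Cn1cc(-c2ccc3nnc(Sc4ccc5ncc(N6CCC(N)C6)cc5c4)n3c2)cn1`: > 8.33 h
- compound 2 `Cn1cc(-c2ccc3nnc(Sc4ccc5ncc(NC6CCOC6)cc5c4)n3c2)cn1`: 0.85 h
- compound 3 `Cn1cc(-c2ccc3nnc(Sc4ccc5ncc(NCCO)cc5c4)n3c2)cn1`: 0.25 h

In an ADME assay on cytosol from liver (strain CD1) for pharmacokinetics, with aldehyde oxidase 1 (Mus musculus) as the target, read by LC-MS, with a stated time of 120 min, tested at 1 uM (on this read-out lower numbers stand for a shorter-lived compound and higher numbers for a longer-lived compound), compound 3 gives 0.25 h, the lowest of the two numbers shown. Compound 2 sits nearest to it, and the step of a 3.4-fold lower number from compound 2 to compound 3 (0.53 log units; beyond the scatter) places compound 3 below it. For compound 1 the result is a limit of the assay, > 8.33 h, as recorded in the limit of > 8.33 h in this assay, at which 1 of the 3 values shown sits; the steps of an at least 9.8-fold lower number from compound 1 to compound 2 (0.99 log units; beyond the scatter) and an at least 33-fold lower number from compound 1 to compound 3 (1.52 log units; beyond the scatter) are therefore lower bounds.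

Compound 4 `Cn1cc(-c2ccc3nnc(Sc4ccc5ncc(NC6CCOCC6)cc5c4)n3c2)cn1` is not yet measured. It differs from compound 3 by oxan-4-yl in place of 2-hydroxyethyl on a nitrogen on an aromatic ring. The step that bears most directly on it is a 3.4-fold lower number from compound 2 to compound 3 (0.53 log units; beyond the scatter), in which exchanging the hydroxyethyl chain for a cyclic ether on the same nitrogen raised the number; oxan-4-yl is a cyclic ether of the same kind, so a step of similar size back upward is expected, a 2.8-fold higher number from compound 3 to compound 4 (0.45 log units; beyond the scatter). Compound 4 is therefore estimated at 0.7 h, within 0.3 h to 2 h.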

Compound 4, half-life: 5.12 h
Beside the measured number, compound 4's estimate is 7.3-fold (0.86 log units) below it, outside the stated range (above it).
By their numbers in this assay, from the lowest: compound 3; then compound 2; then compound 4. At a limit, above all of these: compound 1.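

In this assay, the two cyclic ethers on this nitrogen do not behave alike: oxan-4-yl in place of oxolan-3-yl raises the number by a modest step, a 6.0-fold higher number from compound 2 to compound 4 (0.78 log units; beyond the scatter), so the identity of the ring matters, not merely the presence of a cyclic ether. Against the open chain the change is larger, a 20-fold higher number from compound 3 to compound 4 (1.31 log units; beyond the scatter), so an open-chain to cyclic-ether exchange at this nitrogen has no single size across the compounds shown. Compound 1 stands at a limit: the limit of > 8.33 h in this assay, at which 1 of the 4 values shown sits. The step of an at least 1.6-fold lower number from compound 1 to compound 4 (0.21 log units; that floor lies within the scatter) is a floor only and cannot settle how far apart the two lie.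

The compounds shown leave open whether the rise follows the six-membered ring itself or its ring oxygen. Cyclohexyl or piperidin-4-yl on the same nitrogen would bear directly on that question.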